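The source may hold more compounds than are shown below. What is called first, only, known or untested is meant among the compounds shown, and "the series" means these compounds.

Measured so far: compound 1 `CC(C)C(NC(=O)NO)C(=O)NC1CCCCC1`, compound 2 `CCC(C)C1NC(=O)N(C2CCCCC2)C1=O` and compound 3 `CCC(C)C(NC(=O)NO)C(=O)NC(c1ccccc1)c1ccccc1`.

In a functional assay on L1210 cells (Mus musculus) for inhibition (on this read-out higher numbers stand for weaker inhibition and lower numbers for stronger inhibition), compound 1 gives only a limit, > 100000 nM. Compound 2 likewise gives only a limit, > 200000 nM. Going by the values given here, compound 3 is the one compound with an actual number, 54000 nM. It therefore stands alone among the values shown, as the other two compounds give no number. Compound 4 `CCC(C)C(NC(=O)n1nnc2ccccc21)C(=O)NC(c1ccccc1)c1ccccc1` differs from compound 3 in one place: a group of 9 heavy atoms (6 carbon, 3 nitrogen; one five-membered aromatic ring with 3 hetero atoms, one six-membered aromatic ring of carbon only) in place of a group of 2 heavy atoms (1 nitrogen, 1 oxygen; no ring), on a carbonyl carbon. Among the compounds with values here, no step between measured compounds exists here to guide the size of this change, so the expectation rests on compound 3 alone. Inhibition is expected to become weaker, with a fair chance that only a limit is reported. The estimate for compound 4 is 150000 nM, range 40000 nM to 500000 nM. The expected step is a 2.8-fold higher number from compound 3 to compound 4 (0.44 log units; beyond the scatter).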

Compound 4, half-maximal inhibitory concentration: 17000 nM
Estimate against measurement, compound 4: 8.8-fold (0.95 log units) above, outside the stated range (below it).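

Putting the two-ring aromatic group in place of hydroxyamino on this carbonyl carbon gives, in this assay, a 3.2-fold lower number from compound 3 to compound 4 (0.50 log units; beyond the scatter). The entering group has no hydrogen-bond donors, so the hydroxyamino group is not required for inhibition at this level, although inhibition in both compounds remains weak in absolute terms. Nothing measured here explains why the number falls.

Going by these compounds, whether a single phenyl ring or a plain amine on this carbonyl carbon would give a similar number remains open. So does whether both rings of the entering group are needed.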